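Vero Cell Tolerance Across Three Analogues and a Fourth

The compounds below may be only part of what the source reports. "The series", "measured", "known", "first", "only" and "open" are said of these compounds alone.

Measured in an ADME assay on Vero cells (Chlorocebus sabaeus) for cytotoxicity, read by sulforhodamine B assay, with a stated time of 3 days; a lower number here means that less compound is tolerated, a higher number that more compound is tolerated:
Compound 1 `COc1ccc(C2C(C(=O)Nc3ccc(Cl)cc3)=C(C)NC(C)=C2C(=O)Nc2ccc(Cl)cc2)cc1`: 20 ug/mL
Compound 2 `CC1=C(C(=O)Nc2ccc(Cl)cc2)C(c2ccco2)C(C(=O)Nc2ccc(Cl)cc2)=C(C)N1`: 24 ug/mL
Compound 3 `CC1=C(C(=O)Nc2ccc(Cl)cc2)C(C/C=C/c2ccccc2)C(C(=O)Nc2ccc(Cl)cc2)=C(C)N1`: 21 ug/mL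

Compound 3 sits among three numbers that all lie within the scatter of one another: the step of a 1.1-fold higher number from compound 1 to compound 3 (0.02 log units; within the scatter) and the step of a 1.1-fold lower number from compound 2 to compound 3 (0.06 log units; within the scatter) are both small, as is a 1.2-fold higher number from compound 1 to compound 2 (0.08 log units; within the scatter). Compound 4 `CC1=C(C(=O)Nc2ccc(Cl)cc2)C(c2ccc(N(C)C)cc2)C(C(=O)Nc2ccc(Cl)cc2)=C(C)N1` differs from compound 3 in one place: 4-(dimethylamino)phenyl in place of 3-phenylprop-2-en-1-yl on a saturated ring carbon. Every measured step in this set swaps the group on that same saturated ring carbon, and none of them moved this assay beyond the scatter. On that basis compound 4 is expected to stay close to compound 3, with an estimated step of no change at the digits printed from compound 3 to compound 4 (within the scatter). Compound 4 is therefore estimated at 21 ug/mL, within a range from 12 ug/mL to 38 ug/mL.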

Compound 4, half-maximal cytotoxic concentration: 155 ug/mL
Compound 4: the middle estimate sits 7.4-fold (0.87 log units) below what was measured; the whole stated range lies below it.
By their numbers in this assay, from the lowest: compounds 1, 3 and 2 (each within the scatter of the next); then compound 4.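

In this assay the saturated ring carbon proves sensitive to its group after all: where the earlier swaps stayed within the scatter, 4-(dimethylamino)phenyl gives a 7.4-fold higher number from compound 3 to compound 4 (0.87 log units; beyond the scatter) and a 6.5-fold higher number from compound 2 to compound 4 (0.81 log units; beyond the scatter) in the comparison with the furan-2-yl group. The cleanest comparison is dimethylamino in place of methoxy on an aromatic carbon, which gives a 7.8-fold higher number from compound 1 to compound 4 (0.89 log units; beyond the scatter) and ties the shift to that single substituent. Nothing available explains the shift.

On these data alone, whether it depends on dimethylamino specifically stays open, since a plain amino group, a diethylamino group or a morpholine on that aromatic carbon could separate the amine from its alkyl groups. How a carboxylic acid there would read is equally unknown.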